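Sulfonyl aryl group swap on a piperidinyl-piperidine sulfonamide

This account rests on a few compounds, and the source may have more. Where it says the series, first, only, none or still open, it means among the compounds named here.

Measured compounds:
Compound 1 `Cc1ccc(-c2ccccc2S(=O)(=O)N2CCC(N3CCC(C)CC3)CC2)cc1` — 366 nM
Compound 2 `CC1CCN(C2CCN(S(=O)(=O)c3ccccc3Br)CC2)CC1` — 3 nM
Compound 3 `CC1CCN(C2CCN(S(=O)(=O)c3ccccc3-c3ccccc3)CC2)CC1` — 0.96 nM

In a functional assay on DLD-1 cells (Homo sapiens) for antiproliferative activity, read by CellTiter-Glo, with a stated time of 72 h (a lower number here means a stronger inhibitor, a higher number a weaker inhibitor), compound 2 stands second of the three numbers shown. Its nearest neighbour is compound 3, reached by a 3.1-fold lower number from compound 2 to compound 3 (0.49 log units; beyond the scatter), and its furthest is compound 1, separated by a 120-fold lower number from compound 1 to compound 2 (2.09 log units; beyond the scatter). The step of a 380-fold lower number from compound 1 to compound 3 (2.58 log units; beyond the scatter) shows how much a single methyl can shift the number within this set.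

Compound 4 `CCc1ccc(S(=O)(=O)N2CCC(N3CCC(C)CC3)CC2)cc1` has not yet been measured. It differs from compound 2 in one place: 4-ethylphenyl in place of 2-bromophenyl on a sulfonyl sulfur. No measured step replaces the 2-bromophenyl group as a whole; the steps shown only alter the bromine of compound 2 or add a methyl to compound 3. Among the measured compounds shown here, the step from compound 2 to compound 4 therefore has no direct precedent, and the large spread among the three measured numbers argues for caution. Compound 4 is expected to give a higher number than compound 2, with a 33-fold higher number from compound 2 to compound 4 (1.52 log units; beyond the scatter) as the estimated step. For compound 4 the estimate in this assay is 100 nM, within a range of 10 nM to 1000 nM.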

Compound 4, half-maximal inhibitory concentration: > 5000 nM
Compound 4: only a limit was reported; the forecaster's own chance of this, stated with the estimate: 5%; middle value at least 50-fold (1.69 log units) from the limit.
By their numbers in this assay, from the lowest: compound 3; then compound 2; then compound 1. At a limit, above all of these: compound 4.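

In this assay, compound 4 gives > 5000 nM, which is a limit of the assay and not a number. Among the compounds shown here, replacing the whole group on the sulfonyl sulfur, with 4-ethylphenyl in place of 2-bromophenyl, gives an at least 1600-fold higher number from compound 2 to compound 4 (3.22 log units; beyond the scatter), so this position can lose activity to a degree that the earlier compounds, all with numbers reported, did not reveal. The earlier steps shown here altered only the bromine of compound 2 or a methyl on compound 3, whereas this one shows the outcome of exchanging the entire aryl group.

The compounds shown do not separate the loss of the bromine from the arrival of the ethyl group, and how far the true value of compound 4 lies beyond its limit cannot be read. They also leave open how an unsubstituted phenyl group or a methoxy group on the aryl ring would read in this assay.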